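Judging a Chlorophenyl Variant Against Three Measured Neighbours

A few compounds are considered here, and "the series" means these few. Any claim that something is new, unique, unknown or untested is made for them only; others in the source may bear on it.

Three compounds have been measured in a functional assay on HT-29 cells (Homo sapiens) for cytotoxicity, read by MTT assay, with a stated time of 72 h; on this read-out lower numbers stand for stronger inhibition and higher numbers for weaker inhibition:
Compound 1, `CN(C)CCn1cnnc1-c1cc(Oc2ccc(NC(=O)N/N=C/c3cccc(Br)c3)cc2F)ccn1`, gives 380 nM.
Compound 2, `CN(C)CCn1cnnc1-c1cc(Oc2ccc(NC(=O)N/N=C/c3cccc(O)c3)cc2F)ccn1`, gives 330 nM.
Compound 3, `CN(C)CCn1cnnc1-c1cc(Oc2ccc(NC(=O)N/N=C/c3ccc(F)cc3Cl)cc2F)ccn1`, gives 510 nM.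

Compound 1 has the second highest number of the three. Its nearest neighbour is compound 2, reached by a 1.2-fold lower number from compound 1 to compound 2 (0.06 log units; within the scatter), and its furthest is compound 3, reached by a 1.3-fold higher number from compound 1 to compound 3 (0.13 log units; within the scatter); both steps stay within the scatter, so the three compounds cannot be told apart on these numbers.

Compound 4, `CN(C)CCn1cnnc1-c1cc(Oc2ccc(NC(=O)N/N=C/c3ccc(Cl)cc3)cc2F)ccn1`, has not yet been measured. It differs from compound 1 in one place: 4-chlorophenyl in place of 3-bromophenyl on a carbon with a double bond to nitrogen The two measured steps that touch this same position, from compound 1 to compound 2 and from compound 1 to compound 3, each changed the aromatic ring attached to the carbon with a double bond to nitrogen and each stayed within the scatter. On that basis a step of no more than the scatter is expected in this assay, in no particular direction, when compound 4 is measured. Compound 4 is therefore estimated at 400 nM, within 200 nM to 800 nM, corresponding to an expected 1.1-fold higher number from compound 1 to compound 4 (0.02 log units; within the scatter).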

Compound 4, half-maximal inhibitory concentration: 530 nM
Beside the measured number, compound 4's estimate is 1.3-fold (0.12 log units) below it, within the range that was stated.
By their numbers in this assay, from the lowest: compounds 2, 1, 3 and 4 (each within the scatter of the next).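

Replacing 3-bromophenyl with 4-chlorophenyl on the carbon with a double bond to nitrogen gives a 1.4-fold higher number from compound 1 to compound 4 (0.14 log units; within the scatter) in this assay, so a change of both the halogen and its place on the ring still leaves the number within the scatter. Compound 4 also stays within the scatter of the other two compounds, with a 1.0-fold higher number from compound 3 to compound 4 (0.02 log units; within the scatter) and a 1.6-fold higher number from compound 2 to compound 4 (0.21 log units; within the scatter), so all four rings tried at this position remain indistinguishable in this cell test. No supporting measurement bears on why these steps are so small.

Every group shown here at this position is a substituted phenyl ring, carrying bromo, hydroxy, chloro or both chloro and fluoro. As far as these compounds go, whether a ring bearing a carboxylic acid or a dimethylamino group, or a saturated cyclohexyl ring in place of the phenyl, would stay within the same scatter remains open.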